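This account rests on a few compounds, and the source may have more. Where it says the series, first, only, none or still open, it means among the compounds named here.

Compound 3 `Cn1c(-c2ccccc2Br)cnc1NC(=O)c1ccc(F)cc1` is the anchor of this step. In a toxicity assay on THP-1 cells (Homo sapiens) for inhibition (a lower number here means that less compound is tolerated, a higher number that more compound is tolerated), compound 3 gives > 100000 nM, which is a limit of the assay and not a number. The two neighbours carry limits as well. Compound 1 `COc1ccccc1-c1cnc(NC(=O)c2ccc(F)cc2)n1C` gives > 100000 nM in this assay, a limit. Compound 2 `Cc1ccccc1-c1cnc(NC(=O)c2ccc(F)cc2)n1C` gives > 50000 nM in this assay, also a limit. Compound 3 therefore stands only on a limit, and the comparison set is made of the limit of > 100000 nM in this assay, at which 2 of the 3 values shown sit, and (the limit of > 50000 nM in this assay, at which 1 of the 3 values shown sits). The three measured steps — a step that the two limits leave unreadable from compound 1 to compound 3, a step that the two limits leave unreadable from compound 2 to compound 3 and a step that the two limits leave unreadable from compound 1 to compound 2 — are all unreadable in size. The limits cap both ends of each of them.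

Compound 4 `Cn1c(-c2ccccc2[N+](=O)[O-])cnc1NC(=O)c1ccc(F)cc1` differs from compound 3 by nitro in place of bromo on an aromatic carbon. Going by the values given here, none of the measured steps reads, so no size or direction is inferred for this assay; nitro in place of bromo on an aromatic carbon has no read precedent. The expectation is a further limit: compound 4 in this assay is estimated at 100000 nM, within 50000 nM to 200000 nM. The step of a number no higher from compound 3 to compound 4 (the limit leaves the size open) is expected to be none beyond the scatter.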

Compound 4, half-maximal cytotoxic concentration: 31000 nM
Compound 4: the middle estimate sits 3.2-fold (0.51 log units) above what was measured, and the stated range ends above it.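

Compound 4 is the only compound shown with a number rather than a limit in this assay, so a group at this place, ortho to a large group, can move the read-out. Nitro gives an at least 3.2-fold lower number from compound 3 to compound 4 (0.50 log units; beyond the scatter) and an at least 3.2-fold lower number from compound 1 to compound 4 (0.50 log units; beyond the scatter), while the comparison with methyl reads an at least 1.6-fold lower number from compound 2 to compound 4 (0.20 log units; that floor lies within the scatter), so that step alone does not separate nitro from methyl. Compounds 1, 2 and 3 all stand on limits, and the steps among them cannot be read.

Going by these compounds, whether the lower number is particular to nitro remains open, as an amine, a nitrile or a carboxylic acid at the same place would test that. Nothing in the data shown bears on why the number falls.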